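Three Methoxy Groups Rearranged on a Shared Core

The source may report more compounds than this note shows. Statements on the series, on what has been measured and on what is new or still open speak of the compounds shown alone.

Three compounds with a shared core, differing only in the phenyl group on a double-bonded chain carbon bound to a double-bonded chain carbon, have been tested in a functional assay on SW480 cells (Homo sapiens) for antiproliferative activity, read by sulforhodamine B assay, with a stated time of 48 h; on this read-out lower numbers stand for stronger inhibition and higher numbers for weaker inhibition. In this test compound 1 `COc1cccc(/C=C/C(=O)C(=Cc2ccc(F)cc2)C(=O)/C=C/c2cccc(OC)c2OC)c1OC` gives 1040 nM, compound 2 `COc1cc(C=C(C(=O)/C=C/c2cccc(OC)c2OC)C(=O)/C=C/c2cccc(OC)c2OC)ccc1O` gives 430 nM and compound 3 `COc1cccc(/C=C/C(=O)C(=Cc2cc(OC)c(OC)c(OC)c2)C(=O)/C=C/c2cccc(OC)c2OC)c1OC` gives 650 nM. Compound 3 stands within the scatter of both other compounds, as shown by a 1.6-fold lower number from compound 1 to compound 3 (0.20 log units; within the scatter) and by a 1.5-fold higher number from compound 2 to compound 3 (0.18 log units; within the scatter). Only a 2.4-fold lower number from compound 1 to compound 2 (0.38 log units; beyond the scatter) lies beyond the scatter, and that step is modest.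

Compound 4 `COc1cc(OC)c(C=C(C(=O)/C=C/c2cccc(OC)c2OC)C(=O)/C=C/c2cccc(OC)c2OC)c(OC)c1` has the same atoms as compound 3, joined differently: 2,4,6-trimethoxyphenyl in place of 3,4,5-trimethoxyphenyl on a double-bonded chain carbon bound to a double-bonded chain carbon. Among the measured compounds shown here, no tested compound carries the 2,4,6-trimethoxyphenyl group, so the data offer no direct precedent. For the measured compounds named here, the three steps at this place are the only guide, and they show small differences, with none pointing to a direction for this change. In this assay a large step is therefore not expected, and the estimate stays close to compound 3 at 650 nM. The expected step is a 1.1-fold higher number from compound 3 to compound 4 (0.03 log units; within the scatter), which is estimated to stay within the scatter. For compound 4 the estimated value is 700 nM, with an expected range of 300 nM to 1600 nM.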

Compound 4, half-maximal inhibitory concentration: 840 nM
Compound 4: the middle estimate sits 1.2-fold (0.08 log units) below what was measured; low and high end bracket the measured number.
By their numbers in this assay, from the lowest: compounds 2, 3, 4 and 1 (each within the scatter of the next, the first and the last beyond it).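

Among the compounds shown here, compounds 3 and 4 form the first pair in which only the arrangement of the three methoxy groups on this phenyl group differs, and in this assay that rearrangement leaves the number within the scatter (with a 1.3-fold higher number from compound 3 to compound 4 (0.11 log units; within the scatter)). So on a double-bonded chain carbon bound to a double-bonded chain carbon, 2,4,6-trimethoxyphenyl cannot be told apart from 3,4,5-trimethoxyphenyl in this test. The new group also stays within the scatter of the other two groups (with a 2.0-fold higher number from compound 2 to compound 4 (0.29 log units; within the scatter), and with a 1.2-fold lower number from compound 1 to compound 4 (0.09 log units; within the scatter)), so compound 4, like compound 3, does not separate from either compound 1 or compound 2, although those two lie beyond the scatter of each other. No independent evidence is available to explain these results.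

The four compounds leave open whether the arrangement of substituents matters for groups other than methoxy, such as a dimethylamino group or a carboxylic acid on this phenyl group. They also leave open whether a longer chain in place of a methoxy group, or an amine in place of the phenyl group, would move the number beyond the narrow range seen so far.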